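The source may report more compounds than this note shows. Statements on the series, on what has been measured and on what is new or still open speak of the compounds shown alone.

Of the compounds shown here, three built on one shared core have been measured in a physicochemical assay for solubility, read by HPLC, with a stated time of 4 h, at pH 2; on this read-out higher numbers stand for higher solubility and lower numbers for lower solubility. Compound 1 `COC(=O)c1cc(N)c(Nc2ccc(C#N)cc2)cc1Oc1c(C)cc(/C=C/C#N)cc1C` gives 21.8 ug/mL. Compound 2 `Cc1cc(/C=C/C#N)cc(C)c1Oc1cc(Nc2ccc(C#N)cc2)c(N)cc1C(=O)NCCC(F)F` gives 57.6 ug/mL. Compound 3 `CCNC(=O)c1cc(N)c(Nc2ccc(C#N)cc2)cc1Oc1c(C)cc(/C=C/C#N)cc1C` gives 69.4 ug/mL, the largest of the three numbers, though its difference from compound 2 is within the scatter, whereas a 3.2-fold higher number from compound 1 to compound 3 (0.50 log units; beyond the scatter) and a 2.6-fold higher number from compound 1 to compound 2 (0.42 log units; beyond the scatter) both lie beyond it. Compound 4 `Cc1cc(/C=C/C#N)cc(C)c1Oc1cc(Nc2ccc(C#N)cc2)c(N)cc1C(=O)NN` is not yet measured and differs from compound 3 at one place: amino in place of ethyl on an amide-type nitrogen. Among the measured compounds shown here, no measured step alters a group on the amide-type nitrogen itself; the known steps replace methoxy on the carbonyl carbon, and a 1.2-fold higher number from compound 2 to compound 3 (0.08 log units; within the scatter). A small shift, perhaps slightly upward, is therefore expected, so a 1.4-fold higher number from compound 3 to compound 4 (0.14 log units; within the scatter) is the estimate. Compound 4 is expected to give 95 ug/mL, within 40 ug/mL to 230 ug/mL.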

Compound 4, solubility: 89.6 ug/mL
The estimate for compound 4 lay 1.1-fold (0.03 log units) above the measured number; measured number inside the range.
By their numbers in this assay, from the lowest: compound 1; then compounds 2, 3 and 4 (each within the scatter of the next).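

In this assay, amino in place of ethyl on the amide-type nitrogen gives a 1.3-fold higher number from compound 3 to compound 4 (0.11 log units; within the scatter) and amino in place of 3,3-difluoropropyl gives a 1.6-fold higher number from compound 2 to compound 4 (0.19 log units; within the scatter), so this swap of the group on that nitrogen does not separate these compounds. The clear step remains the one away from methoxy on the carbonyl carbon: aminoamino there gives a 4.1-fold higher number from compound 1 to compound 4 (0.61 log units; beyond the scatter). No measured evidence here explains these numbers. Still open, going by these compounds, is whether a longer chain, a dimethylamino group or a carboxylic acid on this nitrogen would move the number beyond the scatter.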